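Adding a methyl to the ring amide of compound 1

This account rests on a few compounds, and the source may have more. Where it says the series, first, only, none or still open, it means among the compounds named here.

Measured in a functional assay on HBL2 cells (Homo sapiens) for inhibition, read by MTT assay, with a stated time of 48 h; on this read-out higher numbers stand for weaker inhibition of growth and lower numbers for stronger inhibition of growth:
Compound 1 `Nc1nc(Nc2ccccc2)nc2c1CC(c1c(Cl)cccc1Cl)C(=O)N2` gives 5700 nM as a measured number
Compound 2 `Nc1nc(N)c2c(n1)NC(=O)C(c1c(Cl)cccc1Cl)C2` gives > 100000 nM as a limit of the assay
Compound 3 `Nc1nc(Nc2ccccc2)nc2[nH]c(=O)c(-c3c(Cl)cccc3Cl)cc12` gives > 100000 nM as a limit of the assay

Compound 1 is the only one of the three with an actual number, so it cannot be placed within a measured range. The other two values are limits (the limit of > 100000 nM in this assay, at which 2 of the 3 values shown sit). Compound 4 `CN1C(=O)C(c2c(Cl)cccc2Cl)Cc2c(N)nc(Nc3ccccc3)nc21` differs from compound 1 by one change (methyl in place of hydrogen on an amide-type nitrogen in a ring): methyl in place of hydrogen on an amide-type nitrogen in a ring, two ring bonds from the ring atom that bears a 2,6-dichlorophenyl group.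

For the measured compounds named here, only one measured step is available (an at least 17-fold higher number from compound 1 to compound 2 (1.24 log units; beyond the scatter)). It was large, but it concerns hydrogen in place of phenyl on a nitrogen on an aromatic ring, which is a different change at a different place. It shows that one change to this core can cost all measurable inhibition, so the range must stay wide. Going by the values given here, no measured step touches the amide hydrogen, so the expectation stays near compound 1 (5700 nM), with a slight lean towards a higher number in this assay and no step beyond the scatter expected. The expected step is a 1.6-fold higher number from compound 1 to compound 4 (0.20 log units; within the scatter) (an estimate only). Compound 4 is expected at 9000 nM (estimated range 2000 nM to 50000 nM).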

Compound 4, concentration for 50% growth inhibition: 1700 nM
Compound 4: middle estimate off by 5.3-fold (0.72 log units), on the high side; measured number below the stated range.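

In this assay, the amide hydrogen of compound 1 turns out not to be needed for inhibition of growth: methyl in its place gives a 3.4-fold lower number from compound 1 to compound 4 (0.53 log units; beyond the scatter). For the compounds shown here, this is the first measured information on this nitrogen, two ring bonds from the ring atom that bears a 2,6-dichlorophenyl group, as the earlier step, an at least 17-fold higher number from compound 1 to compound 2 (1.24 log units; beyond the scatter), concerned hydrogen in place of phenyl on a nitrogen on an aromatic ring, a different change at a different place. That step ended at compound 2, whose value is a limit of the assay. The new step shows that the core of compound 1 accepts a small added group at the amide nitrogen and that the modest change runs towards stronger inhibition, with compound 4 at 1700 nM.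

On these data alone, whether a longer chain such as ethyl, or a chain ending in an amine or a carboxylic acid, on this same nitrogen would lower the number further or raise it remains open. Nothing shown here bears on why the added methyl lowers the number.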